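The compounds below may be only part of what the source reports. "The series", "measured", "known", "first", "only" and "open" are said of these compounds alone.

In a functional assay on T98G cells (Homo sapiens) for cytotoxicity, read by MTT assay, with a stated time of 48 h (on this read-out lower numbers stand for stronger inhibition and higher numbers for weaker inhibition), compound 1 `C/C(=N\NC(=S)Nc1ccccc1I)c1ccccn1` gives 8.09 nM and compound 2 `CC(=NNC(=S)Nc1cccc(F)c1)c1ccccn1` gives 12 nM, so these two values lie within the usual scatter of each other. Compound 3 `C/C(=N\NC(=S)Nc1ccccc1F)c1ccccn1` has not yet been measured. It has fluoro in place of iodo on an aromatic carbon of compound 1 (fluoro in place of iodo on an aromatic carbon). Among the measured compounds shown here, no measured pair shows this exchange, so the expectation rests on little. Compound 2 also carries fluoro and gives 12 nM. The expected step is small and upward, a 1.9-fold higher number from compound 1 to compound 3 (0.27 log units; within the scatter), and is not expected to clearly exceed the scatter. For compound 3 the estimate is 15 nM, with an expected range of 5 nM to 45 nM.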

Compound 3, half-maximal inhibitory concentration: 3.1 nM
Beside the measured number, compound 3's estimate is 4.8-fold (0.68 log units) above it; measured number below the stated range.
By their numbers in this assay, from the lowest: compound 3; then compounds 1 and 2 (each within the scatter of the next).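

Among the compounds shown here, putting fluoro in place of iodo on this aromatic carbon, ortho to a large group, gives the first single change that can be read here: this assay shows a 2.6-fold lower number from compound 1 to compound 3 (0.42 log units; beyond the scatter) and so responds to what this position carries. Iodo is therefore not required here for a low number. Nothing available explains the step.

From the compounds shown here alone, whether chloro or bromo would fall in line with these two results remains open. So does what an amine or a carboxylic acid at this position would give.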